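This account rests on a few compounds, and the source may have more. Where it says the series, first, only, none or still open, it means among the compounds named here.

In an ADME assay on BJ cells (Homo sapiens) for cytotoxicity, with a stated time of 72 h (on this read-out lower numbers stand for an effect already at smaller amounts and higher numbers for an effect only at larger amounts of compound), compound 1 `Cc1cc(NC(=O)Nc2ccc(C)c(Cl)c2)c2ccccc2n1` gives > 25000 nM, a limit of the assay. Compound 2 `COC(=O)c1ccc(NC(=O)Nc2cc(C)nc3ccccc23)cc1` gives 21000 nM. Compound 3 `Cc1cc(NC(=O)Nc2ccc(C(=O)O)c(O)c2)c2ccccc2n1` gives > 25000 nM, again a limit of the assay.

Among the measured compounds shown here, on this read-out compound 2 holds the only number; the other two values stand at the limit of > 25000 nM in this assay, at which 2 of the 3 values shown sit. Compound 4 `Cc1cc(NC(=O)Nc2ccc(Cl)cc2)c2ccccc2n1` has not yet been measured in this assay. It differs from compound 2 by chloro in place of methoxycarbonyl on an aromatic carbon. For the measured compounds named here, no step between two measured compounds tells how this change plays out; given that compound 2 already lies close to the limit, a step from compound 2 to compound 4 of no more than the usual scatter is expected, with a fair chance that only a limit is reported. Compound 4 is therefore estimated at 26000 nM (range 11000 nM to 60000 nM), an expected step of a 1.2-fold higher number from compound 2 to compound 4 (0.09 log units; within the scatter).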

Compound 4, half-maximal effective concentration: > 25000 nM
Compound 4: a limit, no number (the forecaster's own chance of this, stated with the estimate: 55%); the middle value does not contradict the limit.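

In this assay, chloro in place of methoxycarbonyl on this aromatic carbon, para to a large group, gives an at least 1.1-fold higher number from compound 2 to compound 4 (0.07 log units; that floor lies within the scatter). Among the compounds shown here, this is the first step that can be read at this position, but it has a floor and no upper bound, so its true size remains unknown. Compound 4 joins the compounds that give only a limit: the limit of > 25000 nM in this assay, at which 3 of the 4 values shown sit.

The compounds shown leave open what an amine or a nitrile at this position would give in this assay. They also leave open whether any change to the shared core would give a number clearly lower than that of compound 2.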